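The compounds below may be only part of what the source reports. "The series", "measured", "known", "first", "only" and "open" are said of these compounds alone.

Of the compounds shown here, three have been measured for how well they dissolve. Compound 1 `COc1cccc(CN2C(=O)CN(C(=O)c3cc4cc(OC)ccc4o3)C[C@@H]2CCc2ccccc2)c1` gives 4900 nM in a physicochemical assay for solubility, read by spectrophotometry, in phosphate buffer, with a stated time of 2 h, at pH 7.4; a higher number here means a more soluble compound, a lower number a less soluble compound. Compound 2 `COc1ccc2[nH]c(C(=O)N3CC(=O)N(Cc4ccccc4)[C@@H](CN4CCC(OC)CC4)C3)cc2c1` reaches only a limit of this assay, > 25000 nM, so no number is known for it beyond that boundary (the limit of > 25000 nM in this assay, at which 1 of the 3 values shown sits). Compound 3 `COc1ccc2[nH]c(C(=O)N3CC(=O)N(Cc4ccoc4)[C@@H](Cc4ccccc4)C3)cc2c1`, with a (furan-3-yl)methyl group on the amide-type nitrogen of its core, gives 63600 nM in this assay, the highest of the two numbers. Its gap from compound 1 lies beyond the usual scatter of repeated measurements.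

Compound 4 `COc1ccc2[nH]c(C(=O)N3CC(=O)N(Cc4cccc(OC)n4)[C@@H](Cc4ccccc4)C3)cc2c1` has not yet been measured. It differs from compound 3 in one place: 6-methoxypyridin-2-yl in place of furan-3-yl on a saturated chain carbon bound to an amide-type nitrogen in a ring. Among the compounds with values here, two rings that are different in kind and size are exchanged here, and no pair among the measured compounds shows this exchange on its own, so there is no measured step to lean on. A change of this sort is expected to move solubility only modestly, if at all, and the step from compound 3 to compound 4 is estimated at a 1.6-fold lower number from compound 3 to compound 4 (0.20 log units; within the scatter). On that basis the solubility of compound 4 in this assay is expected to be about 40000 nM, with a plausible range from 15000 nM to 100000 nM.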

Compound 4, solubility: 47500 nM
Compound 4: the middle estimate sits 1.2-fold (0.07 log units) below what was measured, and the stated range covers the measured number.
By their numbers in this assay, from the lowest: compound 1; then compounds 4 and 3 (each within the scatter of the next).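

Within the data shown here, exchanging furan-3-yl for 6-methoxypyridin-2-yl on a saturated chain carbon bound to an amide-type nitrogen in a ring gives, in this assay, a 1.3-fold lower number from compound 3 to compound 4 (0.13 log units; within the scatter), and this is the first step that can be read on its own. The entering group has 8 heavy atoms against 5 and 2 hydrogen-bond acceptors against 1, yet compound 3 and compound 4 cannot be told apart in this read-out, so at this place, for this pair, a six-membered aromatic ring carrying a methoxy group and a five-membered aromatic ring give the same result within the scatter. Nothing measured here bears on why the two compounds match.

As far as these compounds go, both groups compared at this place are uncharged aromatic rings, so it remains open whether a basic amine such as a piperidine, or a carboxylic acid, would give a similar number there. From the compounds shown here alone, it is also open how the ring and its methoxy group each contribute, which a plain pyridin-2-yl group at the same place could help to separate.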